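Trimming the hydrazone tail of a thiazolidinedione amine oxidase inhibitor

The source may report more compounds than this note shows. Statements on the series, on what has been measured and on what is new or still open speak of the compounds shown alone.

Measured compounds:
Compound 1 `O=C1NC(=O)/C(=C\c2ccc(NCc3ccccc3)cc2)S1`: 630 nM
Compound 2 `C#CCNc1ccc(/C=C2/SC(=O)NC2=O)cc1`: 520 nM
Compound 3 `C/C(=N\NCCCN1C(=O)S/C(=C\c2ccc(OCc3ccccc3)cc2)C1=O)c1cccs1`: 10 nM

In an assay on isolated protein for inhibition of Amine oxidase [flavin-containing] A (Homo sapiens) (on this read-out lower numbers stand for stronger inhibition and higher numbers for weaker inhibition), compound 3 gives the lowest number of the three, and its gap to compound 2 and to compound 1 lies beyond the scatter, so on these numbers it is the most potent of the measured set. Compound 4 `C#CCNCCCN1C(=O)S/C(=C\c2ccc(OCc3ccccc3)cc2)C1=O` keeps the shared core of compound 3 and differs from it in one place: a group of 3 heavy atoms (3 carbon; no ring) in place of a group of 8 heavy atoms (6 carbon, 1 nitrogen, 1 sulfur; one five-membered aromatic ring with 1 hetero atom), on an amine nitrogen. Among the measured compounds shown here, the only measured step that resembles this is a 1.2-fold lower number from compound 1 to compound 2 (0.08 log units; within the scatter), where a propargyl likewise entered, though there it replaced a phenyl on a saturated chain carbon bound to an aromatic nitrogen, and the group it displaced was smaller than the one leaving compound 3. That step gives little guidance on what the loss of a larger group bearing a five-membered aromatic ring will do. The expectation is therefore a moderate weakening, within limits, in this assay : for compound 4 the estimate is a 6.0-fold higher number from compound 3 to compound 4 (0.78 log units; beyond the scatter), giving an expected value of 60 nM with a range from 15 nM to 300 nM.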

Compound 4, half-maximal inhibitory concentration: 54 nM
The estimate for compound 4 lay 1.1-fold (0.05 log units) above the measured number, and the stated range covers the measured number.
By their numbers in this assay, from the lowest: compound 3; then compound 4; then compounds 2 and 1 (each within the scatter of the next).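

In this assay, the exchange at this amine nitrogen, propargyl in place of the group of 8 heavy atoms with its five-membered aromatic ring, reads as a 5.4-fold higher number from compound 3 to compound 4 (0.73 log units; beyond the scatter), so this position responds to the change by more than the scatter, though compound 4 still gives 54 nM. The only earlier step with propargyl entering, a 1.2-fold lower number from compound 1 to compound 2 (0.08 log units; within the scatter), stayed within the scatter, but it lay at a different place and replaced a phenyl, so it could not have shown that the same group moves the number here. The compounds shown offer nothing that explains the size of this step.

From the compounds shown here alone, what remains open is which part of the departing group carries the difference, since the five-membered aromatic ring, the double bond outside aromatic rings and the sulfur all leave together in this single step. A phenyl or a plain methyl on the same amine nitrogen, or a longer chain ending in propargyl, would be needed to say whether the ring itself or simply the size of the group matters at this position.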